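Quinoline-isoxazole series: chain homologation near the assay limit

A few compounds are considered here, and "the series" means these few. Any claim that something is new, unique, unknown or untested is made for them only; others in the source may bear on it.

Compound 1 `CCCCc1cc2ccccc2nc1-c1cc(-c2ccc(C)cc2)no1` and compound 2 `CCCCCc1cc2ccccc2nc1-c1cc(-c2ccc(C)cc2)no1` share a core that carries a tolyl-bearing ring. In a functional assay on COLO 205 cells (Homo sapiens) for inhibition, read by MTT assay, with a stated time of 24 h (a lower number here means a stronger inhibitor, a higher number a weaker inhibitor), compound 1 gives only a limit, > 100000 nM. In this assay compound 2 likewise gives only a limit, > 100000 nM. The change between them is methyl in place of hydrogen on a saturated chain carbon, four bonds along the chain from an aromatic carbon, and the step that the two limits leave unreadable from compound 1 to compound 2 cannot be read because of the limit of > 100000 nM in this assay, at which 3 of the 3 values shown sit. Compound 3 `CCc1cc2ccccc2nc1-c1cc(-c2ccc(C(F)(F)F)cc2)no1` bears a trifluoromethyl-substituted ring; the difference between the cores of compound 1 and compound 3 is not broken down here. In this assay compound 3 gives only a limit, > 100000 nM. Compound 4 `CCCc1cc2ccccc2nc1-c1cc(-c2ccc(C(F)(F)F)cc2)no1` differs from compound 3 by methyl in place of hydrogen on a saturated chain carbon, two bonds along the chain from an aromatic carbon, the same kind of change as from compound 1 to compound 2 but placed two bonds, not four, along the chain from an aromatic carbon. Given that all three values sit at the limit, the step of a number no higher from compound 3 to compound 4 (the limit leaves the size open) is expected to be small or unreadable. Compound 4 is expected to give about 100000 nM, most likely again a limit.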

Compound 4, half-maximal inhibitory concentration: 42200 nM
The estimate for compound 4 lay 2.4-fold (0.37 log units) above the measured number; the whole stated range lies above it.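

In this assay, methyl in place of hydrogen on a saturated chain carbon, two bonds along the chain from an aromatic carbon, gives an at least 2.3-fold lower number from compound 3 to compound 4 (0.37 log units; beyond the scatter) on the core with the trifluoromethyl-substituted ring. This shows that the change can lower the number on that core, but not that it does so on the tolyl-bearing core, where the change also sits four bonds along the chain. That step cannot be read, so nothing shows whether the effect carries from one core to the other, because both of its values are limits: the limit of > 100000 nM in this assay, at which 3 of the 4 values shown sit.

The compounds shown leave open how far the number would move with a longer chain on the core of compound 4. They also leave open whether an amine or a carboxylic acid in place of the chain would give a readable value.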